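Anilino change from compound 3 to compound 4

A few compounds are considered here, and "the series" means these few. Any claim that something is new, unique, unknown or untested is made for them only; others in the source may bear on it.

For the measured compounds named here, the three measured members share one core and differ in the two groups on the amine nitrogen and in the aryl ring on the anilino nitrogen. Compound 1 `C=CCN(CC=C)c1nc(C)nc(Nc2c(C)cccc2C)n1` carries two allyl groups and a 2,6-dimethylphenyl ring; in an assay on isolated protein for binding affinity to corticotropin-releasing factor receptor 1 (Homo sapiens) (on this read-out higher numbers stand for weaker inhibition and lower numbers for stronger inhibition), compound 1 gives only a limit, > 10000 nM. Compound 2 `CCCN(CC1CC1)c1nc(C)nc(Nc2ccc(OC)cc2OC)n1` carries propyl and cyclopropylmethyl with a 2,4-dimethoxyphenyl ring, and in this assay compound 2 gives 8000 nM. Compound 3 `CCCN(Cc1ccccc1)c1nc(C)nc(Nc2ccc(C)cc2)n1` carries propyl and benzyl with a 4-methylphenyl ring. In this assay compound 3 gives only a limit, > 10000 nM. Compound 3 therefore stands at the edge of what the method reports, the place where two of the three values sit (the limit of > 10000 nM in this assay, at which 2 of the 3 values shown sit); no number is known for it and its distance to compound 2 cannot be stated. Compound 4 `CCCN(Cc1ccccc1)c1nc(C)nc(Nc2c(C)cc(C)cc2C)n1` keeps propyl and benzyl and differs from compound 3 by 2,4,6-trimethylphenyl in place of 4-methylphenyl on a nitrogen on an aromatic ring. Going by the values given here, no measured pair among the three shows a change of this kind. The expected step of an at least 6.6-fold lower number from compound 3 to compound 4 (0.82 log units; beyond the scatter) is a gain in this assay beyond the usual scatter, with a real chance that the reading again stops at a limit. Compound 4 is estimated at 1500 nM, with a range from 200 nM to 10000 nM.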

Compound 4, inhibition constant: 490 nM
Beside the measured number, compound 4's estimate is 3.1-fold (0.49 log units) above it, and the stated range covers the measured number.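

In this assay, with propyl and benzyl held fixed on the amine nitrogen, 2,4,6-trimethylphenyl in place of 4-methylphenyl on a nitrogen on an aromatic ring gives an at least 20-fold lower number from compound 3 to compound 4 (1.30 log units; beyond the scatter), a large step beyond the scatter. For the compounds shown here, this is the first change that can be read in one place, and it shows that the aryl group at this position alone can bring a compound off the limit and into the measurable range, with the amine groups untouched. Compound 3 gives > 10000 nM, which is a limit and not a number, so the step is a bound and its full size stays unknown: the limit of > 10000 nM in this assay, at which 2 of the 4 values shown sit.

On these data alone, whether the gain needs every methyl group of 2,4,6-trimethylphenyl, and whether an aryl ring with chlorine or bromine in place of those methyl groups would hold it, remains open. As far as these compounds go, the effect of the amine groups on their own also remains open, for example a butyl chain in place of propyl or a cyclohexylmethyl group in place of benzyl with 2,4,6-trimethylphenyl kept.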